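The source may hold more compounds than are shown below. What is called first, only, known or untested is meant among the compounds shown, and "the series" means these compounds.

Compound 1 `Oc1cccc(-c2cc(-c3cccc(F)c3)cc(-c3ccccc3O)n2)c1`: > 50000 nM
Compound 2 `Oc1cccc(-c2cc(-c3ccc(F)cc3)cc(-c3ccccc3O)n2)c1`: > 50000 nM

Both measured compounds share a core carrying a 2-hydroxyphenyl group and a 3-hydroxyphenyl group, and differ only in the third aryl group. In a functional assay on DU-145 cells (Homo sapiens) for inhibition (on this read-out lower numbers stand for stronger inhibition and higher numbers for weaker inhibition), compound 1 gives > 50000 nM, which is a limit of the assay and not a number. Compound 2 likewise gives > 50000 nM in this assay, again a limit rather than a measured value. The step that the two limits leave unreadable from compound 1 to compound 2 therefore cannot be read, since (the limit of > 50000 nM in this assay, at which 2 of the 2 values shown sit). Compound 3 `Oc1cccc(-c2cc(-c3cccc(C(F)(F)F)c3)cc(-c3ccccc3O)n2)c1` is not yet measured; it differs from compound 2 by 3-(trifluoromethyl)phenyl in place of 4-fluorophenyl on an aromatic carbon. Going by the values given here, the only measured step, from compound 1 to compound 2, changes the same group, but its size is hidden by the two limits, so it offers no direction for compound 3. With both measured compounds at the limit, the expected step that the limit leaves unreadable from compound 2 to compound 3 is one that keeps compound 3 near that limit. Compound 3 is therefore expected to give 80000 nM in this assay, between 20000 nM and 300000 nM, most likely reported only as a limit.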

Compound 3, half-maximal inhibitory concentration: 13000 nM
Compound 3: the middle estimate sits 6.2-fold (0.79 log units) above what was measured; measured number outside the range, below it.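

This position opposite the ring nitrogen, which gave no readable signal with either fluorophenyl group, can carry a measurable response: in this assay, 3-(trifluoromethyl)phenyl in place of 4-fluorophenyl gives an at least 3.8-fold lower number from compound 2 to compound 3 (0.58 log units; beyond the scatter) and brings the series off the limit. With the substituent kept on the same ring carbon, trifluoromethyl in place of fluoro gives an at least 3.8-fold lower number from compound 1 to compound 3 (0.58 log units; beyond the scatter), so this single exchange on the 3-substituted phenyl ring is enough to separate compound 3 from compound 1. Both steps are lower bounds and the step between compound 1 and compound 2 cannot be read, since only compound 3 has a number: the limit of > 50000 nM in this assay, at which 2 of the 3 values shown sit.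

The compounds shown leave open how far the response depends on trifluoromethyl itself and how far on its place on the phenyl ring, a question that 4-(trifluoromethyl)phenyl at this position would address. They also leave open whether a larger or different group there, such as a methoxy, a nitrile, an amine or a carboxylic acid on that phenyl ring, would lower the number further or return it to the limit.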